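The source may hold more compounds than are shown below. What is called first, only, known or untested is meant among the compounds shown, and "the series" means these compounds.

Measured in a functional assay on A549 cells (Homo sapiens) for cytotoxicity, read by MTT assay, with a stated time of 48 h; on this read-out higher numbers stand for weaker inhibition and lower numbers for stronger inhibition:
- compound 1 `C=C1C(=O)O[C@H]2CC3=C[C@H](C/C(C)=C/[C@@H](OC(=O)c4ccc(C(F)(F)F)cc4)[C@H]12)OC3=O`: > 10000 nM
- compound 2 `C=C1C(=O)O[C@H]2CC3=C[C@H](C/C(C)=C/[C@@H](OC(=O)CCl)[C@H]12)OC3=O`: > 10000 nM

Compound 2 gives > 10000 nM, and this is a limit, not a number. Compound 1 gives > 10000 nM, which is also a limit. Both compounds therefore stand at the limit of > 10000 nM in this assay, at which 2 of the 2 values shown sit.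

Compound 3 `C=C1C(=O)O[C@H]2CC3=C[C@H](C/C(C)=C/[C@@H](OC(=O)C4CC4)[C@H]12)OC3=O` has cyclopropyl in place of chloromethyl on a carbonyl carbon.

Going by the values given here, one measured step bears on this place: a step that the two limits leave unreadable from compound 1 to compound 2. It offers no size to carry over, so the data support no particular direction or size of change in this assay. Compound 3 is expected to remain weak, resting on compound 2 with its limit of > 10000 nM. The expected change is a step that the limit leaves unreadable from compound 2 to compound 3. For compound 3 the estimated value is 15000 nM, with an expected range from 5000 nM to 40000 nM.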

Compound 3, half-maximal inhibitory concentration: 3200 nM
Compound 3: middle estimate off by 4.7-fold (0.67 log units), on the high side; the measured number lies below the stated range.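

In this assay this place on the shared core now shows a readable change, with cyclopropyl in place of chloromethyl on a carbonyl carbon giving an at least 3.1-fold lower number from compound 2 to compound 3 (0.49 log units; beyond the scatter). Cyclopropyl in place of 4-(trifluoromethyl)phenyl at the same place gives an at least 3.1-fold lower number from compound 1 to compound 3 (0.49 log units; beyond the scatter), whereas the step between compound 1 and compound 2 cannot be read. Compound 3 is the only one of the three with a number, and the values of the other two are limits: the limit of > 10000 nM in this assay, at which 2 of the 3 values shown sit.

As far as these compounds go, the full size of both readable steps remains open, as does any order between compound 1 and compound 2. The compounds shown also leave open whether a cyclobutyl ring, an isopropyl group or a longer alkyl chain at this place would give a value like that of compound 3 or a limit like those of the other two.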